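The source may report more compounds than this note shows. Statements on the series, on what has been measured and on what is new or still open speak of the compounds shown alone.

Measured so far in an in vivo ADME assay on the whole organism for pharmacokinetics, with Rattus norvegicus as the target; on this read-out higher numbers stand for higher oral bioavailability and lower numbers for lower oral bioavailability:
- compound 1 `CCn1nccc1NC1=C(C(N)=O)NNc2c(C)cc(S(=O)(=O)CC)cc21`: 41%
- compound 2 `Cc1cc(S(C)(=O)=O)cc2c1NNC(C(N)=O)=C2Nc1cccc(C#N)c1`: 17%

Compound 2 holds the lower of these two numbers, and the gap up to compound 1 lies beyond the usual scatter of repeated measurements. The two compounds differ in more than one place, so their gap cannot be tied to any single group.

The next compound, compound 3 `Cc1cc(S(C)(=O)=O)cc2c1NNC(C(N)=O)=C2Nc1cncc(F)c1`, keeps everything in compound 2 except one group: 5-fluoropyridin-3-yl stands in place of 3-cyanophenyl on an amine nitrogen (5-fluoropyridin-3-yl in place of 3-cyanophenyl on an amine nitrogen). Among the measured compounds shown here, no measured pair shows a single change of this kind, so any forecast here is rough. For the measured compounds named here, the starting point is compound 2 at 17%, and the only higher number available is compound 1 at 41%. A small rise is therefore expected, most likely not beyond the scatter, and the estimated step of a number 7 percentage points higher from compound 2 to compound 3 (within the scatter) reflects that. In this assay, the expected value for compound 3 is 24%, with an estimated range of 10% to 42%.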

Compound 3, oral bioavailability in the Rattus norvegicus assay: 34%
The estimate for compound 3 lay 10 percentage points below the measured number; measured number inside the range.
By their numbers in the Rattus norvegicus assay, from the lowest: compound 2; then compounds 3 and 1 (each within the scatter of the next).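

Among the compounds shown here, in the Rattus norvegicus assay, 5-fluoropyridin-3-yl in place of 3-cyanophenyl on the amine nitrogen gives a number 17 percentage points higher from compound 2 to compound 3 (beyond the scatter), the first single change that can be read here, and it shows that the group at this place alone can shift oral bioavailability. In a physicochemical assay for solubility (on this read-out lower numbers stand for lower solubility and higher numbers for higher solubility), the same change gives a much larger response: a 37-fold higher number from compound 2 to compound 3 (1.57 log units; beyond the scatter). In the physicochemical assay compound 2 stands at 1 ug/mL and compound 3 at 37 ug/mL in this comparison. The two read-outs rise together, so one possible reading is that more of compound 3 dissolves and this helps it reach the blood after an oral dose, although a single pair cannot prove that link: the measured solubility of compound 2, 1 ug/mL, and of compound 3, 37 ug/mL, a 37-fold higher number (1.57 log units; beyond the scatter)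

This change removes the nitrile and brings in both a ring nitrogen and a fluorine, so the pair cannot show which of these differences accounts for either rise. As far as these compounds go, a 3-fluorophenyl group or an unsubstituted pyridin-3-yl group on the same amine nitrogen would pull these differences apart, and how either would behave in the two read-outs remains open.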